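Losing the 2-fluorophenyl group: compound 3 to compound 4

A few compounds are considered here, and "the series" means these few. Any claim that something is new, unique, unknown or untested is made for them only; others in the source may bear on it.

- compound 1 `CN(C)C(=O)c1cc2cnc(Nc3ccc(NC(=O)C4(C(=O)Nc5ccc(Cl)cc5)CC4)cc3)nc2n1C1CCCC1`: 8.1%
- compound 2 `CN(C)C(=O)c1cc2cnc(Nc3ccc(NC(=O)C4(C(=O)Nc5cccc(O)c5)CC4)cc3)nc2n1C1CCCC1`: 58.5%
- compound 3 `CN(C)C(=O)c1cc2cnc(Nc3ccc(NC(=O)C4(C(=O)Nc5ccccc5F)CC4)cc3)nc2n1C1CCCC1`: 58%

All three values come from a functional assay on OVCAR-5 cells (Homo sapiens) for inhibition, read by CCK-8 assay, with a stated time of 72 h, tested at 1 uM; on this read-out higher numbers stand for more inhibition of growth at the one concentration tested and lower numbers for less inhibition of growth. Compound 3, at 58%, stands level with compound 2: the measured step is a number 0.5 percentage points lower from compound 2 to compound 3 (within the scatter). Both stand well clear of compound 1, with steps of a number 50.4 percentage points higher from compound 1 to compound 2 (beyond the scatter) and a number 49.9 percentage points higher from compound 1 to compound 3 (beyond the scatter).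

The next compound is compound 4 `CN(C)C(=O)c1cc2cnc(Nc3ccc(NC(=O)C4(C(=O)Nc5ccc(Br)cc5)CC4)cc3)nc2n1C1CCCC1`, which has 4-bromophenyl in place of 2-fluorophenyl on an amide-type nitrogen. Going by the values given here, no bromophenyl compound has been measured. The closest evidence is compound 1, which carries 4-chlorophenyl at the same place and gives 8.1%. The step of a number 49.9 percentage points higher from compound 1 to compound 3 (beyond the scatter) therefore bears most directly, read in reverse, since compound 4 leaves the 2-fluorophenyl group for a group resembling that of compound 1 in name. Among the compounds with values here, the step of a number 0.5 percentage points lower from compound 2 to compound 3 (within the scatter) adds only that two quite different groups gave matching values.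

A large fall is therefore expected, resting on this one compound, so the upper end of the range is kept wide. The expected change is a number 43 percentage points lower from compound 3 to compound 4 (beyond the scatter). For compound 4 the estimated value is 15%, with an expected range from 2% to 40%.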

Compound 4, percent growth inhibition at one concentration: 13.7%
Compound 4: the middle estimate sits 1.3 percentage points above what was measured, within the range that was stated.
By their numbers in this assay, from the lowest: compounds 1 and 4 (each within the scatter of the next); then compounds 3 and 2 (each within the scatter of the next).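

With the 4-bromophenyl group on the amide-type nitrogen, the read-out in this assay falls sharply on both available comparisons: a number 44.3 percentage points lower from compound 3 to compound 4 (beyond the scatter), and a number 44.8 percentage points lower from compound 2 to compound 4 (beyond the scatter). Bromo in place of chloro on an aromatic carbon gives a number 5.6 percentage points higher from compound 1 to compound 4 (within the scatter), so the low value of compound 1 is now matched by a second compound, and these two halogens are not told apart at this position in this read-out. No measurement at hand accounts for the gap between these two low compounds and the pair carrying 2-fluorophenyl and 3-hydroxyphenyl.

The step from compound 3 to compound 4 changes the halogen and its place on the aromatic ring together, so these compounds cannot show which of the two matters, and the four aryl groups do not say whether any substituent is needed at all, a question that a plain phenyl group would address. On these data alone, how a methoxyphenyl or an aminophenyl group would compare also stays open, as does whether the values at this single concentration would keep their order at other concentrations.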